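The source may report more compounds than this note shows. Statements on the series, on what has been measured and on what is new or still open speak of the compounds shown alone.

In a functional assay on the whole organism (Ear, strain Kunming) for inhibition, with Mus musculus as the target, with stated times of 1 h and 30 min, at a dose of 200 mg/kg by the oral route (a higher number here means more inhibition at the dose given (going by the name of the read-out), a lower number less inhibition), compound 1 `CN(CC1CCC/C(=C\c2ccc(S(C)(=O)=O)cc2)C1=O)c1ccccc1` gives 46.9%. Compound 2 `Cc1cccc(N(C)CC2CCC/C(=C\c3ccc(S(C)(=O)=O)cc3)C2=O)c1` carries methyl in place of hydrogen on an aromatic carbon and in this assay compound 2 gives 36.7%, so the change produced a number 10.2 percentage points lower from compound 1 to compound 2 (beyond the scatter). Compound 3 `COc1ccc(C2(O)/C(=C/c3ccc(C)cc3)CCCC2CN(C)c2ccccc2)cc1` rests on a different core, and how the two cores differ is not broken down here; in this assay compound 3 gives 16.3%. Compound 4 `COc1ccc(C2(O)/C(=C/c3ccc(C)cc3)CCCC2CN(C)c2ccc(C)cc2)cc1` has not yet been measured and carries methyl in place of hydrogen on an aromatic carbon. This is the same kind of change as the one before, not the same: there the methyl sits meta to a large group, here para to a large group. For compound 4 a step of similar size is expected, a number 5.3 percentage points lower from compound 3 to compound 4 (within the scatter). That expectation rests only on the earlier methyl step, a number 10.2 percentage points lower from compound 1 to compound 2 (beyond the scatter), on another core. Compound 4 is therefore estimated at 11%.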

Compound 4, a percentage reported as inhibition, in the whole organism at one dose (the size of the read-out at that dose, not a potency): 29.9%
Estimate against measurement, compound 4: 18.9 percentage points below; the measured number lies above the stated range.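

In this assay the added methyl gives a number 13.6 percentage points higher from compound 3 to compound 4 (beyond the scatter) and so runs the opposite way to the same change on the core of compound 1. The direction of this step therefore did not carry over from one core to the other: the same change on two cores in this assay, a number 10.2 percentage points lower (beyond the scatter) from compound 1 to compound 2 and a number 13.6 percentage points higher (beyond the scatter) from compound 3 to compound 4, 23.8 percentage points apart, beyond the scatter of two such steps. Among these compounds, this does not show the reason, since the methyl in compound 4 sits para to a large group and the one in compound 2 does not, and a single pair on each core cannot separate the role of the core from that of the position.

The compounds shown leave open whether a larger alkyl group such as ethyl, a chlorine atom or an amine at that place would behave like methyl. They also leave open whether either core would give the same direction at other doses.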